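This account rests on a few compounds, and the source may have more. Where it says the series, first, only, none or still open, it means among the compounds named here.

Of the compounds shown here, three of one family have been tested in a functional assay on RPMI-8226 cells (Homo sapiens) for cytotoxicity, read by sulforhodamine B assay, with a stated time of 48 h; a higher number here means that more compound is tolerated, a lower number that less compound is tolerated. Compound 1 `ClCc1cccc(Cn2cnc3c(Cl)ncnc32)c1` gives 87100 nM in this assay. Compound 2 `ClCc1ccc(Cn2cnc3nc(Cl)nc(Cl)c32)cc1` gives 97700 nM in this assay, a number within the scatter of compound 1. For compound 3 `ClCc1cccc(Cn2cnc3c(Cl)nc(Cl)nc32)c1` this assay reports only a limit, > 100000 nM, not a number. That is the limit of > 100000 nM in this assay, at which 1 of the 3 values shown sits. The difference between the core of compound 2 and the core of compound 3 is not broken down here. Compound 1 arises from compound 3 by hydrogen in place of chloro on an aromatic carbon, and this change gave an at least 1.1-fold lower number from compound 3 to compound 1 (0.05 log units; that floor lies within the scatter). Compound 4 `ClCc1ccc(Cn2cnc3ncnc(Cl)c32)cc1` has not yet been measured; it arises from compound 2 by the same change, (hydrogen in place of chloro on an aromatic carbon). Resting on that earlier step an at least 1.1-fold lower number from compound 3 to compound 1 (0.05 log units; that floor lies within the scatter), the expected step is a 1.1-fold lower number from compound 2 to compound 4 (0.06 log units; within the scatter). For compound 4 the estimate in this assay is 85000 nM, expected to fall between 45000 nM and 100000 nM.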

Compound 4, concentration lethal to 50% of the cells: 5620 nM
Compound 4: middle estimate off by 15-fold (1.18 log units), on the high side, and the stated range ends above it.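

In this assay, hydrogen in place of chloro on an aromatic carbon gave a 17-fold lower number from compound 2 to compound 4 (1.24 log units; beyond the scatter), a large step on the core of compound 2. This does not show that the change carries from one core to the other with the same size, nor that its size depends on the core, and the two cases stand as follows: the same change on two cores in this assay, an at least 1.1-fold lower number (0.05 log units; that floor lies within the scatter) from compound 3 to compound 1 and a 17-fold lower number (1.24 log units; beyond the scatter) from compound 2 to compound 4; the limit leaves it open whether they differ. The value of compound 3 is a limit and not a number: the limit of > 100000 nM in this assay, at which 1 of the 4 values shown sits.

The compounds shown leave open how an amine or a methoxy group would compare with chloro and hydrogen on that same carbon. They also leave open how this change would behave on any further core.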